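Chloro on the pyridine-side ring: two cores compared

The source may hold more compounds than are shown below. What is called first, only, known or untested is meant among the compounds shown, and "the series" means these compounds.

Measured in an assay on U2OS cells for activation of nuclear factor erythroid 2-related factor 2 (Homo sapiens), read by beta-arrestin recruitment, with a stated time of 6 h; a higher number here means that more compound is needed for the effect, a lower number that less compound is needed:
compound 1 `O=S(=O)(/C=C/c1ccccn1)c1ccccc1Cl` gives 618 nM
compound 2 `O=S(=O)(/C=C/c1ccc(Cl)cn1)c1ccccc1Cl` gives 2940 nM
compound 3 `O=S(=O)(/C=C/c1cccnc1)c1cccc(Cl)c1` gives 3520 nM

Compound 1 and compound 3 have the same atoms joined differently; the difference between the two cores is not broken down here. Compound 3 has the highest number of the three, yet against compound 2 this gap is within the scatter; against compound 1 it is beyond it.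

Within the core of compound 1, one change is on record: chloro in place of hydrogen on an aromatic carbon. It gives a 4.8-fold higher number from compound 1 to compound 2 (0.68 log units; beyond the scatter).

Compound 4 `O=S(=O)(/C=C/c1ccc(Cl)nc1)c1cccc(Cl)c1` is not yet measured. It differs from compound 3 in the same kind of change: chloro in place of hydrogen on an aromatic carbon. The two places are not the same: in compound 2 the chloro stands two atoms from the ring nitrogen, in compound 4 next to the ring nitrogen. Within the data shown here, a step of the size of the earlier one, or somewhat smaller, is expected as a 3.1-fold higher number from compound 3 to compound 4 (0.49 log units; beyond the scatter), resting on the single change from compound 1 to compound 2 and on compound 3 as its starting point; the different place and the different core make the carry-over uncertain. For compound 4 the expected value in this assay is 11000 nM, within 4000 nM to 30000 nM.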

Compound 4, half-maximal effective concentration: 2210 nM
The estimate for compound 4 lay 5.0-fold (0.70 log units) above the measured number; the measured number lies below the stated range.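

In this assay, chloro in place of hydrogen on an aromatic carbon gives a 1.6-fold lower number from compound 3 to compound 4 (0.20 log units; within the scatter), so the rise seen on the core of compound 1 does not carry over to the core of compound 3, and the two steps differ: the same change on two cores in this assay, a 4.8-fold higher number (0.68 log units; beyond the scatter) from compound 1 to compound 2 and a 1.6-fold lower number (0.20 log units; within the scatter) from compound 3 to compound 4, 7.6-fold (0.88 log units) apart, beyond the scatter of two such steps

On the core of compound 3, the step is within the scatter, so this change cannot be told from repeat measurement there. Among these compounds, the data do not show whether the core or the place of the chloro sets the difference, since the two steps differ in both, with the chloro in compound 4 next to the ring nitrogen and no pair holding one fixed while the other varies.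

Open, going by these compounds, is whether chloro at the same place on each of the two cores would give matching steps. Also open, on these data alone, is how a group other than chloro on that aromatic carbon, such as an amine, a methoxy group or a carboxylic acid, would read in this assay.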